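Swapping 3-methylthiophen-2-yl for pyridin-3-yl: forecast for compound 3

This account rests on a few compounds, and the source may have more. Where it says the series, first, only, none or still open, it means among the compounds named here.

Compound 1 `Cc1ccsc1-c1ccnc(Nc2ccc(N(C)C)cc2)n1` holds the only numerical read-out in the set: in a functional assay for inhibition, with Homo sapiens as the target (on this read-out higher numbers stand for weaker inhibition and lower numbers for stronger inhibition), compound 1 gives 1800 nM. Compound 2 `COc1cccc(Nc2nc(C)cc(-c3ccncc3)n2)c1` yields only a limit of this assay, > 24000 nM. That limit is where one of the two shown values sits (the limit of > 24000 nM in this assay, at which 1 of the 2 values shown sits). For the measured compounds named here, no pair of measured compounds differs in a single place, so no measured step is available to lean on.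

Compound 3 `CN(C)c1ccc(Nc2nccc(-c3cccnc3)n2)cc1` differs from compound 1 at one site: pyridin-3-yl in place of 3-methylthiophen-2-yl on an aromatic carbon. With nothing measured for this kind of change, the step is expected to be a modest loss of potency, a little beyond the usual scatter; the expected step is a 2.2-fold higher number from compound 1 to compound 3 (0.35 log units; beyond the scatter). Compound 3 is therefore estimated at 4000 nM, with a range from 1000 nM to 16000 nM.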

Compound 3, half-maximal inhibitory concentration: 2800 nM
The estimate for compound 3 lay 1.4-fold (0.15 log units) above the measured number, and the stated range covers the measured number.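

At this aromatic carbon next to the ring nitrogen, the first single-site change read in this assay gives a 1.6-fold higher number from compound 1 to compound 3 (0.19 log units; within the scatter), so 3-methylthiophen-2-yl and pyridin-3-yl cannot be told apart at this site. The position thus accepts a six-membered aromatic ring with one nitrogen in place of a five-membered aromatic ring with one sulfur, without a change that can be read in this series. No measured property shown here bears on this result.

Still open, going by these compounds, is whether this site accepts groups of a different kind, such as a saturated amine like morpholine or a carboxylic acid. Also open is what the dimethylamino group shared by compound 1 and compound 3 contributes, as no compound shown changes that group alone.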